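Propargyl urea in the anilinoquinazoline urea series

A few compounds are considered here, and "the series" means these few. Any claim that something is new, unique, unknown or untested is made for them only; others in the source may bear on it.

For the measured compounds named here, compound 3 `CN1CCN(C(=O)Nc2cc3c(Nc4ccc(F)c(Cl)c4)ncnc3cc2O[C@H]2CCOC2)CC1` gives 675 nM in a functional assay on A-431 cells (Homo sapiens) for antiproliferative activity, read by sulforhodamine B assay, with a stated time of 72 h; on this read-out higher numbers stand for weaker inhibition and lower numbers for stronger inhibition; this is the second highest of the three numbers measured so far. Compound 2 `CN(C)CCCNC(=O)Nc1cc2c(Nc3ccc(F)c(Cl)c3)ncnc2cc1O[C@H]1CCOC1` gives 226 nM, and compound 1 `COC(CCNC(=O)Nc1cc2c(Nc3ccc(F)c(Cl)c3)ncnc2cc1O[C@H]1CCOC1)OC` gives 22000 nM. The measured steps are a 97-fold lower number from compound 1 to compound 2 (1.99 log units; beyond the scatter), a 33-fold lower number from compound 1 to compound 3 (1.51 log units; beyond the scatter) and a 3.0-fold higher number from compound 2 to compound 3 (0.48 log units; beyond the scatter).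

Compound 4 `C#CCNC(=O)Nc1cc2c(Nc3ccc(F)c(Cl)c3)ncnc2cc1O[C@H]1CCOC1` differs from compound 3 by propargylamino in place of 4-methylpiperazin-1-yl on a carbonyl carbon. Going by the values given here, the steps that bear on this change are the two that exchange the group on the carbonyl carbon: a 3.0-fold higher number from compound 2 to compound 3 (0.48 log units; beyond the scatter) was modest, whereas a 33-fold lower number from compound 1 to compound 3 (1.51 log units; beyond the scatter) was large. Compound 4 carries neither the dimethoxypropyl chain of compound 1 nor the 4-methylpiperazin-1-yl of compound 3, so the large step is only a partial guide; the expected outcome is a higher number in this assay, of a size between the two reference steps, i.e. an estimated step of a 2.2-fold higher number from compound 3 to compound 4 (0.35 log units; beyond the scatter). For compound 4 the estimate in this assay is 1500 nM, with a range from 300 nM to 8000 nM.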

Compound 4, half-maximal inhibitory concentration: 3730 nM
The estimate for compound 4 lay 2.5-fold (0.40 log units) below the measured number; low and high end bracket the measured number.
By their numbers in this assay, from the lowest: compound 2; then compound 3; then compound 4; then compound 1.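

In this assay, propargylamino on the carbonyl carbon gives a number on the weaker side of both groups carrying a further amine (a 5.5-fold higher number from compound 3 to compound 4 (0.74 log units; beyond the scatter); a 17-fold higher number from compound 2 to compound 4 (1.22 log units; beyond the scatter)). It still stays on the stronger side of the dimethoxypropyl chain (a 5.9-fold lower number from compound 1 to compound 4 (0.77 log units; beyond the scatter)), so among the groups without a further amine, the number at this position also moves with the group chosen. Across these four compounds, the two with a further amine in the group, compound 2 and compound 3, give the lowest numbers, and neither compound 1 nor compound 4 goes against this. No measurement shown accounts for these differences.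

The compounds shown leave open what the triple bond contributes, which a saturated propylamino group would test directly. As far as these compounds go, whether a longer alkynyl chain or a morpholine ring at this carbonyl carbon would fall nearer compound 2 also remains open.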